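Swapping Neopentyl for Cyclohexyl in Compound 4

The compounds below may be only part of what the source reports. "The series", "measured", "known", "first", "only" and "open" are said of these compounds alone.

In an ADME assay on liver for metabolic stability, with Liver microsome (Homo sapiens) as the target, read by LC-MS, using microsomes (a lower number here means slower removal, a higher number faster removal of the compound), compound 1 `CC(C)(C)[C@@H](O)C(=O)N1C[C@@H]2C[C@@H]2[C@H]1C(=O)NCc1cc(Cl)ccc1-n1cnnn1` gives only a limit, < 15 mL.min-1.g-1. Compound 3 `CC(C)(C)C[C@@H](O)C(=O)N1C[C@@H]2C[C@@H]2[C@H]1C(=O)NCc1cc(Cl)ccc1-n1cnnn1` gives 20 mL.min-1.g-1 and compound 2 `COC(C)(C)[C@@H](O)C(=O)N1C[C@H]2C[C@H]2[C@H]1C(=O)NCc1cc(Cl)ccc1-n1cnnn1` gives 23 mL.min-1.g-1, two values within the scatter of each other. Compound 4 `O=C(NCc1cc(Cl)ccc1-n1cnnn1)[C@@H]1[C@H]2C[C@H]2CN1C(=O)[C@H](O)C1CCCCC1` differs from compound 3 by one change, cyclohexyl in place of neopentyl on a saturated chain carbon bound to a carbonyl carbon and an oxygen on a saturated carbon. Among the measured compounds shown here, the one measured step at this place is an at least 1.3-fold higher number from compound 1 to compound 3 (0.12 log units; that floor lies within the scatter), with tert-butyl replaced by neopentyl. On these data alone, it starts from a limit, so its true size is unknown, and it offers no sign of a large effect. The expected change is small and within the scatter, a 1.3-fold higher number from compound 3 to compound 4 (0.11 log units; within the scatter). Compound 4 is estimated at 26 mL.min-1.g-1, with an expected range from 15 mL.min-1.g-1 to 45 mL.min-1.g-1.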

Compound 4, intrinsic clearance in microsomes: 110 mL.min-1.g-1
Compound 4: the middle estimate sits 4.2-fold (0.63 log units) below what was measured; measured number above the stated range.
By their numbers in this assay, from the lowest: compounds 3 and 2 (each within the scatter of the next); then compound 4. At a limit, below all of these: compound 1.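

Among the compounds shown here, at this place, on a saturated chain carbon bound to a carbonyl carbon and an oxygen on a saturated carbon, the earlier compounds showed no step beyond the scatter, yet in this assay cyclohexyl in place of neopentyl gives a 5.5-fold higher number from compound 3 to compound 4 (0.74 log units; beyond the scatter). Cyclohexyl in place of tert-butyl gives an at least 7.3-fold higher number from compound 1 to compound 4 (0.86 log units; beyond the scatter). The value of compound 1 is a limit, so only the floor of that step is known: the limit of < 15 mL.min-1.g-1 in this assay, at which 1 of the 4 values shown sits.

The compounds shown do not tell whether the ring itself or the extra carbon matters. A cyclopentyl or a tetrahydropyranyl group at this place would test that.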